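Bromo in place of hydrogen on compound 2

The compounds below may be only part of what the source reports. "The series", "measured", "known", "first", "only" and "open" are said of these compounds alone.

In a functional assay on SW480 cells (Homo sapiens) for antiproliferative activity, read by sulforhodamine B assay, with a stated time of 48 h (a lower number here means a stronger inhibitor, a higher number a weaker inhibitor), compound 1 `COc1cccc(/C=C/C(=O)C(=Cc2cc(OC)c(OC)c(OC)c2)C(=O)/C=C/c2cccc(OC)c2OC)c1OC` gives 650 nM, while compound 2 `COc1ccc(/C=C/C(=O)C(=Cc2ccc(O)c(OC)c2)C(=O)/C=C/c2ccc(OC)cc2OC)c(OC)c1` gives 1520 nM. Compound 2 therefore holds the higher of the two numbers, and the gap between them lies beyond the scatter. Compound 3 `COc1ccc(/C=C/C(=O)C(=Cc2cc(Br)c(O)c(OC)c2)C(=O)/C=C/c2ccc(OC)cc2OC)c(OC)c1` carries bromo in place of hydrogen on an aromatic carbon of compound 2, ortho to a hydroxy group, so that 4-hydroxy-3-methoxyphenyl becomes 3-bromo-4-hydroxy-5-methoxyphenyl (bromo in place of hydrogen on an aromatic carbon). Among the measured compounds shown here, no two measured compounds differ in one place only, so the series gives no direct precedent for this change. In this assay a small move towards a lower number is expected, but none beyond the scatter. The expected change is a 1.4-fold lower number from compound 2 to compound 3 (0.14 log units; within the scatter). For compound 3 the estimated value is 1100 nM, with an estimated range of 450 nM to 2600 nM.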

Compound 3, half-maximal inhibitory concentration: 1480 nM
Beside the measured number, compound 3's estimate is 1.3-fold (0.13 log units) below it; measured number inside the range.
By their numbers in this assay, from the lowest: compound 1; then compounds 3 and 2 (each within the scatter of the next).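

Among the compounds shown here, the step of a 1.0-fold lower number from compound 2 to compound 3 (0.01 log units; within the scatter) is the first direct reading of a single change, taken in this assay. At this place, on an aromatic carbon ortho to a hydroxy group and meta to a methoxy group, bromo in place of hydrogen leaves compound 3 indistinguishable from compound 2, so this position accepts one bromine atom with no readable cost or gain. Nothing measured here bears on why the two compounds read alike.

Going by these compounds, whether this position stays as permissive for chloro, an amine or a carboxylic acid remains open, as does whether bromo reads the same with the hydroxy group replaced by methoxy. Compound 1 differs from compound 3 in more than one place, so its lower number cannot yet be assigned to any single group.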